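The source may hold more compounds than are shown below. What is called first, only, known or untested is meant among the compounds shown, and "the series" means these compounds.

Within the data shown here, in an ADME assay on a cell-free system (plasma, Homo sapiens) for metabolic stability, read by HPLC, tested at 5 mM (on this read-out higher numbers stand for a longer-lived compound and lower numbers for a shorter-lived compound), compound 1 (`C[C@@H](O)[C@H]1C(=O)N2C(C(=O)OCOC(=O)OC3Cc4ccccc4C3)=C(S[C@@H]3CN[C@H](C(=O)N(C)C)C3)[C@H](C)[C@H]12`) gives 0.0717 h, the lower of the two numbers measured so far, while compound 2 (`C[C@@H](O)[C@H]1C(=O)N2C(C(=O)OCOC(=O)O[C@@H]3CCCCc4ccccc43)=C(S[C@@H]3CN[C@H](C(=O)N(C)C)C3)[C@H](C)[C@H]12`) gives 0.567 h. Compound 3 (`C[C@@H](O)[C@H]1C(=O)N2C(C(=O)OCOC(=O)OC3CCc4ccccc4C3)=C(S[C@@H]3CN[C@H](C(=O)N(C)C)C3)[C@H](C)[C@H]12`) differs from compound 1 by 1,2,3,4-tetrahydronaphthalen-2-yl in place of 2,3-dihydro-1H-inden-2-yl on an oxygen next to a carbonyl group. Among the measured compounds shown here, only one measured step bears on this, a 7.9-fold higher number from compound 1 to compound 2 (0.90 log units; beyond the scatter), which is beyond the scatter and swaps the group at the same place for one with a seven-membered non-aromatic ring. With a six-membered ring entering, a smaller rise in the same direction is expected, estimated as a 2.5-fold higher number from compound 1 to compound 3 (0.40 log units; beyond the scatter). The estimated half-life of compound 3 is 0.18 h, within a range of 0.07 h to 0.5 h.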

Compound 3, half-life in the plasma assay: 0.135 h
Estimate against measurement, compound 3: 1.3-fold (0.12 log units) above; measured number inside the range.
By their numbers in the plasma assay, from the lowest: compounds 1 and 3 (each within the scatter of the next); then compound 2.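

In the plasma assay, compound 3 gives 0.135 h, and the 1,2,3,4-tetrahydronaphthalen-2-yl group on an oxygen next to a carbonyl group cannot be told apart from 2,3-dihydro-1H-inden-2-yl (a 1.9-fold higher number from compound 1 to compound 3 (0.27 log units; within the scatter)), while the group with the seven-membered non-aromatic ring stands apart (a 4.2-fold lower number from compound 2 to compound 3 (0.62 log units; beyond the scatter)). In a physicochemical assay for metabolic stability, read by HPLC, with a stated time of 120 min, at pH 6, tested at 100 uM (on this read-out higher numbers stand for a more stable compound and lower numbers for a less stable compound), compound 1 gives 96% and compound 3 gives 93%; the same swap also stays within the scatter (a number 3 percentage points lower from compound 1 to compound 3 (within the scatter)), so neither read-out separates these two groups. Nothing given here explains these numbers. Going by these compounds, how an amine, a carboxylic acid or a longer chain would behave on this oxygen remains open.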